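Oxolan-3-yl to 3,3,3-trifluoropropyl on the shared core

This account rests on a few compounds, and the source may have more. Where it says the series, first, only, none or still open, it means among the compounds named here.

In an ADME assay on microsomes from liver (Rattus norvegicus) for metabolic stability, with a stated time of 30 min, tested at 1 uM (a higher number here means that more of the compound is left, a lower number that less of the compound is left), compound 2 (`CC[C@@H]1C(=O)N(C)c2cnc(-n3ccnc3-c3ccccc3)nc2N1[C@@H]1CCOC1`) gives 0% and stands lowest of the three measured compounds. Compound 3 (`CCC1C(=O)N(C)c2cnc(-n3ccnc3-c3ccc(F)cc3)nc2N1c1ccc(F)cc1`) gives 11% there, and compound 1 (`CC[C@@H]1C(=O)N(C)c2cnc(-c3cn[nH]c3-c3ccc(F)cc3F)nc2N1c1cnn(C)c1`) gives 13% there. Both lie beyond the scatter above compound 2 and within the scatter of each other.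

Compound 4 (`CC[C@@H]1C(=O)N(C)c2cnc(-n3ccnc3-c3ccccc3)nc2N1CCC(F)(F)F`) differs from compound 2 in one place, with 3,3,3-trifluoropropyl in place of oxolan-3-yl on a nitrogen on an aromatic ring in a ring. For the measured compounds named here, no two measured compounds differ in only one place, so no measured step speaks directly to this change. With compound 2 at 0% in this read-out, only an upward step can register. Compound 1 at 13% and compound 3 at 11% carry other groups on that nitrogen and still keep little of the compound, so a large rise is not expected. The expected change is a number 8 percentage points higher from compound 2 to compound 4 (within the scatter) in an upward direction, a small step not clearly beyond the scatter. In this assay compound 4 is estimated at 8% (expected range 0% to 25%).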

Compound 4, percent of the compound remaining: 0%
The estimate for compound 4 lay 8 percentage points above the measured number, and the stated range covers the measured number.
By their numbers in this assay, from the lowest: compounds 2 and 4 (each within the scatter of the next); then compounds 3 and 1 (each within the scatter of the next).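

In this assay the exchange of oxolan-3-yl for 3,3,3-trifluoropropyl on this nitrogen gives no change at the digits printed from compound 2 to compound 4 (within the scatter), and this is the only one-place change in the compounds shown. At this position, the five-membered ring, its hydrogen-bond acceptor and its defined stereocentre can all give way to an open fluorinated chain without the number leaving the bottom of the read-out, where any further loss between the two compounds cannot show. No available evidence bears on why the number stays there.

Open, as far as these compounds go, is whether any other group on this nitrogen, such as a cyclopropyl ring, a plain n-propyl chain or a chain ending in a morpholine, would lift the number off the bottom of the read-out on this same core. Also open, from the compounds shown here alone, is how the same exchange reads from a starting compound with a number above the bottom of the read-out, with different groups elsewhere on the core, where a step in either direction could register.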